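The source may hold more compounds than are shown below. What is called first, only, known or untested is meant among the compounds shown, and "the series" means these compounds.

Measured so far:
- compound 1, `OCCC(NC1CCN(CCCc2c[nH]c3ccc(-n4cnnc4)cc23)CC1)c1ccccc1`: in a functional assay on CHO cells for activation of 5-hydroxytryptamine receptor 1D (Homo sapiens), read by GTPgammaS binding (on this read-out higher numbers stand for larger maximal responses and lower numbers for smaller maximal responses), compound 1 gives 100%
- compound 2, `COC[C@H](NC1CCN(CCCc2c[nH]c3ccc(-n4cnnc4)cc23)CC1)c1ccccc1`: compound 2 gives 93%
- compound 3, `C[C@@H](NC1CCN(CCCc2c[nH]c3ccc(-n4cnnc4)cc23)CC1)c1ccccc1`: compound 3 gives 90%

Compound 3 has the lowest of the three numbers, yet both its neighbours lie within the usual scatter: a number 3 percentage points lower from compound 2 to compound 3 (within the scatter) and a number 10 percentage points lower from compound 1 to compound 3 (within the scatter). Compound 4, `CC(=O)Nc1ccc(CNC2CCN(CCCc3c[nH]c4ccc(-n5cnnc5)cc34)CC2)cc1`, differs from compound 3 at the same amine nitrogen that the other changes touched: 4-acetamidobenzyl in place of 1-phenylethyl on an amine nitrogen. All three measured steps swap the group on that nitrogen, and none moved the response beyond the scatter, including a number 7 percentage points lower from compound 1 to compound 2 (within the scatter). Within the data shown here, the new group is larger and carries a donor and an acceptor, which none of the measured groups have, so the precedent is only partial. Still, no step beyond the scatter is expected. Compound 4 is estimated to give 90%, from 72% to 100%. The expected step is no change at the digits printed from compound 3 to compound 4 (within the scatter).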

Compound 4, largest response reached (reported as efficacy), in percent of the reference or control that the assay uses: 75%
The estimate for compound 4 lay 15 percentage points above the measured number; the range from low to high includes it.
By their numbers in this assay, from the lowest: compound 4; then compounds 3, 2 and 1 (each within the scatter of the next).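

Among these compounds, at the amine nitrogen, the group can change the maximal response after all: in this assay, 4-acetamidobenzyl gives a number 15 percentage points lower from compound 3 to compound 4 (beyond the scatter), a number 18 percentage points lower from compound 2 to compound 4 (beyond the scatter) and a number 25 percentage points lower from compound 1 to compound 4 (beyond the scatter), the first steps at this position beyond the scatter. Nothing shown here tells why the response fell. The change also alters two things at once, removing the branching methyl of 1-phenylethyl and adding the acetamido group. Which of these goes with the lower response stays open; a plain benzyl group on the same nitrogen would separate them.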